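Removing a difluoromethyl from compound 1

The compounds below may be only part of what the source reports. "The series", "measured", "known", "first", "only" and "open" are said of these compounds alone.

Measured compounds:
compound 1, `O=c1c(-c2ccc(OC(F)F)cc2)coc2cc(OC(F)F)cc(O)c12`, 5.54 uM
compound 2, `CCCCCCCCCCOc1ccc(-c2coc3cc(OCCCCCCCCCC)cc(O)c3c2=O)cc1`, 4.27 uM

Of the compounds shown here, two have been measured in a functional assay on SGC-7901 cells (Homo sapiens) for inhibition, read by MTT assay; a lower number here means a stronger inhibitor of growth, a higher number a weaker inhibitor of growth. Compound 1 gives 5.54 uM, and compound 2 gives 4.27 uM. Compound 1 thus has the higher of the two numbers, but its distance to compound 2 lies within the scatter of repeated measurements, so the two cannot be told apart on these data.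

The next compound, compound 3, `O=c1c(-c2ccc(O)cc2)coc2cc(OC(F)F)cc(O)c12`, has not yet been measured in this assay. It differs from compound 1 in one place:

hydrogen in place of difluoromethyl on an oxygen on an aromatic ring

Among the compounds with values here, no step between measured compounds involves this change, so nothing in the data says how large it should be. With so little to go on, the writer expects the step in this assay to be small, in no settled direction, and probably not beyond the scatter; the estimated step of a 1.1-fold higher number from compound 1 to compound 3 (0.03 log units; within the scatter) reflects this. Compound 3 is therefore expected to give about 6 uM, with a range from 2 uM to 18 uM.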

Compound 3, concentration for growth inhibition (reported as GI): 4.59 uM
For compound 3 the middle estimate is 1.3-fold (0.12 log units) above the measured one; measured number inside the range.
By their numbers in this assay, from the lowest: compounds 2, 3 and 1 (each within the scatter of the next).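

In this assay, replacing the difluoromethyl on an oxygen on an aromatic ring with hydrogen, which turns difluoromethoxy into hydroxy, gives a 1.2-fold lower number from compound 1 to compound 3 (0.08 log units; within the scatter). Within the data shown here, this is the first step that can be read at this place, and it shows that the loss of 3 heavy atoms there leaves compound 1 and compound 3 indistinguishable in this measure of growth inhibition. No measurement among the data shown bears on why the step is this size.

The compounds shown leave open whether the insensitivity extends beyond this one exchange: a methyl or an amine-bearing chain on the same oxygen could still separate from compound 1 and compound 3, and only hydrogen and difluoromethyl can be compared directly here. Among these compounds, they also leave open what the difluoromethoxy shared by compound 1 and compound 3 on the core contributes, since compound 2 differs from each of them in more than one place and gives no step that isolates either group.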